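This account rests on a few compounds, and the source may have more. Where it says the series, first, only, none or still open, it means among the compounds named here.

Series notes. Compound 1 `COc1ccc(C(=O)/C=C/c2cccc(F)c2)c2c1C=CC(C)(C)O2` and compound 2 `CCN(CC)c1ccc(/C=C/C(=O)c2ccc(OC)c3c2OC(C)(C)C=C3)cc1` share the same core and differ only in the ring carried on the enone. In a functional assay on K562 cells (Homo sapiens) for antiproliferative activity, read by MTT assay, with a stated time of 24 h (a higher number here means a weaker inhibitor, a lower number a stronger inhibitor), compound 2 gives 790 nM. Compound 1 reaches only a limit of the assay in this assay, > 10000 nM. Within the data shown here, compound 2 thus stands as the only actual number in this assay, the other value being a limit, (the limit of > 10000 nM in this assay, at which 1 of the 2 values shown sits). Compound 3 `COc1ccc(C(=O)/C=C/c2ccc([N+](=O)[O-])cc2)c2c1C=CC(C)(C)O2` is not yet measured. It differs from compound 2 in one place: nitro in place of diethylamino on an aromatic carbon, a nitro in place of diethylamino on an aromatic carbon. Among the measured compounds shown here, no measured pair differs in exactly this way, so this step has no direct precedent in this assay. The expectation is a loss of potency beyond the usual scatter, a step of a 6.3-fold higher number from compound 2 to compound 3 (0.80 log units; beyond the scatter) in this assay. Compound 3 is estimated at 5000 nM, with a range from 1000 nM to 20000 nM, and a fair chance that only a limit is reported.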

Compound 3, half-maximal inhibitory concentration: 7770 nM
Estimate against measurement, compound 3: 1.6-fold (0.19 log units) below; the measured number falls inside the stated range.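

Nitro in place of diethylamino on an aromatic carbon, para to a large group, gives a 9.8-fold higher number from compound 2 to compound 3 (0.99 log units; beyond the scatter) in this assay, the first actual measure of how much this position responds to a change of group. The step with 4-nitrophenyl in place of 3-fluorophenyl is an at least 1.2-fold lower number from compound 1 to compound 3 (0.10 log units; that floor lies within the scatter), so only a floor is known for it and no order can be drawn there. Of the three compounds, only the diethylamino compound stands clearly apart from the nitro compound, and the comparison at the weak end still rests on a limit: the limit of > 10000 nM in this assay, at which 1 of the 3 values shown sits.

From the compounds shown here alone, whether the value of compound 2 depends on the amine nitrogen or on its ethyl chains stays open. A smaller amine such as dimethylamino, a cyclic amine such as morpholine, or a carboxylic acid at the same carbon would help separate the two.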